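The compounds below may be only part of what the source reports. "The series", "measured", "known", "first", "only" and "open" are said of these compounds alone.

Compound 1 `COc1ccc(C2CC(=O)c3ccc(C)cc3O2)cc1`, compound 2 `COc1ccc2c(c1)OC(c1ccc(C)cc1)CC2=O` and compound 3 `Cc1ccc2c(c1)OC(c1ccccc1)CC2=O` were measured in an in vitro assay on BTI-TN-5B1-4 cells for inhibition of Amine oxidase [flavin-containing] B (Homo sapiens); a higher number here means a weaker inhibitor, a lower number a stronger inhibitor. Compound 1 gives 3350 nM, compound 2 gives 550 nM and compound 3 gives 3620 nM, so compound 2 is the strongest inhibitor of the three. Compound 1 and compound 2 are built from the same atoms joined differently; the difference between the two cores is not broken down here. From compound 1 to compound 3 the change is hydrogen in place of methoxy on an aromatic carbon and the step is a 1.1-fold higher number from compound 1 to compound 3 (0.03 log units; within the scatter). Compound 4 `Cc1ccc(C2CC(=O)c3ccccc3O2)cc1` has not yet been measured. It differs from compound 2 by hydrogen in place of methoxy on an aromatic carbon, the same kind of change, but here the methoxy leaves an aromatic carbon of the fused system, meta to a fused ring and para to a fused ring, rather than one para to a large group. Going by the values given here, only the single step of a 1.1-fold higher number from compound 1 to compound 3 (0.03 log units; within the scatter), at a different place, is available as a guide, and compound 2 stands well apart from the others, so the expectation is uncertain; a step of a 3.1-fold higher number from compound 2 to compound 4 (0.49 log units; beyond the scatter) in this assay is expected. Compound 4 is thus estimated to give 1700 nM, with a likely range from 500 nM to 6000 nM.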

Compound 4, half-maximal inhibitory concentration: 2070 nM
Beside the measured number, compound 4's estimate is 1.2-fold (0.09 log units) below it, and the stated range covers the measured number.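

In this assay, hydrogen in place of methoxy on an aromatic carbon of the fused system gives a 3.8-fold higher number from compound 2 to compound 4 (0.58 log units; beyond the scatter). Going by these compounds alone, this change therefore does not carry over from one core to the other with a single size: the same change on two cores in this assay, a 1.1-fold higher number (0.03 log units; within the scatter) from compound 1 to compound 3 and a 3.8-fold higher number (0.58 log units; beyond the scatter) from compound 2 to compound 4, 3.5-fold (0.54 log units) apart, beyond the scatter of two such steps The two pairs show only that the step cannot be transferred unchanged, and they do not separate the place of the methoxy from the rest of the core, since the two differ together here.

The compounds shown leave open how an amine, a hydroxyl or a longer alkoxy chain would behave at the same aromatic carbon. They also leave open whether the methoxy of compound 2 would give a similar step on any further core.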